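The compounds below may be only part of what the source reports. "The series", "measured", "known", "first", "only" and "open" are said of these compounds alone.

Measured so far:
Compound 1 `COc1ccc(C(=O)N(CCN2CCC(OCC(=O)O)CC2)c2ccc(C)cc2)cc1`: 1200 nM
Compound 2 `Cc1ccc(N(CCN2CCC(OCC(=O)O)CC2)C(=O)c2cccc(C)c2)cc1`: 160 nM
Compound 3 `Cc1ccc(N(CCN2CCC(OCC(=O)O)CC2)C(=O)c2cccc(C(F)(F)F)c2)cc1`: 20000 nM

In a functional assay on a cell-free system (Platelet, plasma, Homo sapiens) for inhibition (on this read-out lower numbers stand for stronger inhibition and higher numbers for weaker inhibition), compound 2 stands lowest of the three, at 160 nM. Compound 4 `Cc1cccc(C(=O)N(CCN2CCC(OCC(=O)O)CC2)c2ccc(Cl)cc2)c1` differs from it in one place: chloro in place of methyl on an aromatic carbon. Among the measured compounds shown here, no measured step touches this 4-methylphenyl. The measured steps all change the group on the carbonyl: a 7.5-fold lower number from compound 1 to compound 2 (0.88 log units; beyond the scatter), a 17-fold higher number from compound 1 to compound 3 (1.22 log units; beyond the scatter) and a 130-fold higher number from compound 2 to compound 3 (2.10 log units; beyond the scatter). They show that single swaps there can move the number far, but they do not size this change. A small move towards a higher number is expected, and the estimated step is a 1.6-fold higher number from compound 2 to compound 4 (0.19 log units; within the scatter). For compound 4 the estimated value is 250 nM, with an expected range of 60 nM to 1000 nM.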

Compound 4, half-maximal inhibitory concentration: 310 nM
Beside the measured number, compound 4's estimate is 1.2-fold (0.09 log units) below it, and the stated range covers the measured number.
By their numbers in this assay, from the lowest: compounds 2 and 4 (each within the scatter of the next); then compound 1; then compound 3.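

Changing 4-methylphenyl to 4-chlorophenyl gives a 1.9-fold higher number from compound 2 to compound 4 (0.29 log units; within the scatter) in this assay, the only step shown at this position. Here, chloro in place of methyl on the aromatic carbon para to a large group leaves the two compounds within the scatter of each other, whereas each step on the carbonyl side lies beyond it. No available evidence explains this result. The compounds shown leave open whether an amine or a nitrile at this position would also stay within the scatter of compound 2, and whether chloro would behave the same way with another group on the carbonyl.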